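Furan-2-yl in place of thiophen-2-yl on the shared core

A few compounds are considered here, and "the series" means these few. Any claim that something is new, unique, unknown or untested is made for them only; others in the source may bear on it.

In a functional assay on HeLa cells (Homo sapiens) for cytotoxicity, read by ELISA, with a stated time of 2 days (on this read-out higher numbers stand for weaker inhibition and lower numbers for stronger inhibition), compound 1 `Oc1cccc(-c2cc(-c3ccccc3)cc(-c3ccco3)n2)c1` gives 9430 nM and compound 2 `Oc1ccc(-c2cc(-c3ccccc3)cc(-c3cccs3)n2)cc1` gives 1700 nM, the lower of the two numbers and a gap beyond the scatter. Compound 3 `Oc1ccc(-c2cc(-c3ccccc3)cc(-c3ccco3)n2)cc1` has furan-2-yl in place of thiophen-2-yl on an aromatic carbon, next to the ring nitrogen (furan-2-yl in place of thiophen-2-yl on an aromatic carbon). Going by the values given here, no measured pair isolates this change. Compound 1 also carries furan-2-yl but differs from compound 2 in more than one place, so compound 1 at 9430 nM is only a weak guide. A modest move towards a higher number in this assay is expected, with the estimated step of a 1.8-fold higher number from compound 2 to compound 3 (0.25 log units; within the scatter). For compound 3 the estimated value is 3000 nM, with an expected range of 1100 nM to 8000 nM.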

Compound 3, half-maximal inhibitory concentration: 10900 nM
The estimate for compound 3 lay 3.6-fold (0.56 log units) below the measured number; the whole stated range lies below it.
By their numbers in this assay, from the lowest: compound 2; then compounds 1 and 3 (each within the scatter of the next).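

In this assay, going by these compounds alone, furan-2-yl in place of thiophen-2-yl on an aromatic carbon, next to the ring nitrogen, gives a 6.4-fold higher number from compound 2 to compound 3 (0.81 log units; beyond the scatter) as the first clean reading of this change, favouring thiophen-2-yl at this position. With furan-2-yl held, 4-hydroxyphenyl in place of 3-hydroxyphenyl gives a 1.2-fold higher number from compound 1 to compound 3 (0.06 log units; within the scatter) and does not separate the two compounds. Nothing available accounts for either step.

Open, going by these compounds, is whether a pyridin-2-yl ring or an amine at this position would match thiophen-2-yl. Also open, on these data alone, is whether 3-hydroxyphenyl and 4-hydroxyphenyl stay inseparable with thiophen-2-yl in place.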